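This account rests on a few compounds, and the source may have more. Where it says the series, first, only, none or still open, it means among the compounds named here.

In a functional assay on J774 cells (Mus musculus) for cytotoxicity, with a stated time of 48 h (on this read-out lower numbers stand for stronger inhibition and higher numbers for weaker inhibition), compound 3 `CC(C)C[C@@H](NC(=O)OC(C)(C)C)C(=O)N1CCC[C@@H]1C(=O)N1[C@H](C(=O)OCc2ccccc2)[C@H]1C(=O)OCc1ccccc1` gives > 100000 nM, which is a limit of the assay and not a number. Compound 1 `CC(C)C[C@@H](NC(=O)OC(C)(C)C)C(=O)N1CCC[C@H]1C(=O)N1[C@H](C(=O)OCc2ccccc2)[C@H]1C(=O)OCc1ccccc1` gives > 100000 nM, also a limit. Compound 2 `CC(C)(C)OC(=O)NCC(=O)N1CCC[C@@H]1C(=O)N1[C@H](C(=O)OCc2ccccc2)[C@H]1C(=O)OCc1ccccc1` gives > 100000 nM, again a limit. Within the data shown here, the whole set therefore comes down to the limit of > 100000 nM in this assay, at which 3 of the 3 values shown sit, so no compound can be ranked against another.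

Compound 4 `CC(C)C[C@H](NC(=O)OC(C)(C)C)C(=O)N1CCC[C@@H]1C(=O)N1[C@H](C(=O)OCc2ccccc2)[C@H]1C(=O)OCc1ccccc1` has the same atoms and bonds as compound 3, and the change is this: the two compounds have the same atoms and bonds and differ only in configuration as drawn: 1 of 4 stereo elements differ; a stereocentre at a saturated chain carbon is drawn R in compound 3 and S in compound 4.

Among the measured compounds shown here, the closest precedent is also a change of configuration, here at a saturated ring carbon. It is a step that the two limits leave unreadable from compound 1 to compound 3, and it rests on (the fact that compounds 1 and 3 differ only in the configuration as drawn). The other measured step, isobutyl in place of hydrogen, is a step that the two limits leave unreadable from compound 2 to compound 3. Neither step has a readable size, so neither points to a shift in either direction, and no change beyond the scatter is expected in this assay. The expected outcome is a number no higher from compound 3 to compound 4 (the limit leaves the size open). For compound 4 the estimated value is 100000 nM, within an expected range of 50000 nM to 200000 nM.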

Compound 4, half-maximal inhibitory concentration: > 100000 nM
Compound 4 gave a limit, no number; the forecaster's own chance of this, stated with the estimate: 85%; the middle value sits exactly at the limit.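

In this assay compound 4 gives > 100000 nM, which is a limit and not a number. Among these compounds, compounds 1, 2 and 3 also sit at limits, so no new step to compound 4 can be read. The compounds shown leave open whether configuration or the isobutyl group affects this read-out at all.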